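The compounds below may be only part of what the source reports. "The series", "measured", "known", "first", "only" and "open" are said of these compounds alone.

In a functional assay on PC-3 cells (Homo sapiens) for cytotoxicity, read by resazurin assay, with a stated time of 48 h (on this read-out lower numbers stand for stronger inhibition and higher numbers for weaker inhibition), compound 3 `C=C(C)[C@@H]1CC=C(CN(OC)C2O[C@H](CN=[N+]=[N-])[C@@H](O)[C@H](O)[C@H]2O)CC1` gives 182000 nM, within the scatter of compound 1 `C=C(C)[C@@H]1CC=C(CN(OC)C2OC[C@@H](O)[C@H](O)[C@H]2O)CC1` at 152000 nM, while compound 2 `C=C(C)[C@@H]1CC=C(CN(OC)C2O[C@H](CNC(=O)CCCCCCCCC)[C@@H](O)[C@H](O)[C@H]2O)CC1` gives a lower 30000 nM. Compound 4 `C=CCOC(=O)NC[C@H]1OC(N(CC2=CC[C@@H](C(=C)C)CC2)OC)[C@H](O)[C@@H](O)[C@@H]1O` differs from compound 3 by (allyloxycarbonyl)amino in place of azido on a saturated chain carbon bound to a saturated ring carbon. Within the data shown here, the one measured step that bears on this, a 1.2-fold higher number from compound 1 to compound 3 (0.08 log units; within the scatter), offers little guidance. Among the measured compounds shown here, compound 2, the only measured compound with an acylated nitrogen in place of azido, stands at 30000 nM, so a modest move to a lower number is expected in this assay. The expected change is a 2.3-fold lower number from compound 3 to compound 4 (0.36 log units; beyond the scatter). For compound 4 the estimate is 80000 nM, with an expected range of 32000 nM to 180000 nM.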

Compound 4, half-maximal inhibitory concentration: 232000 nM
Compound 4: middle estimate off by 2.9-fold (0.46 log units), on the low side, outside the stated range (above it).
By their numbers in this assay, from the lowest: compound 2; then compounds 1, 3 and 4 (each within the scatter of the next).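

In this assay, (allyloxycarbonyl)amino in place of azido on this saturated chain carbon gives a 1.3-fold higher number from compound 3 to compound 4 (0.11 log units; within the scatter), and ((allyloxycarbonyl)amino)methyl in place of hydrogen on the saturated ring carbon gives a 1.5-fold higher number from compound 1 to compound 4 (0.18 log units; within the scatter), so neither change separates these compounds. An acylated nitrogen alone therefore does not bring the lower number, since allyloxy in place of nonyl on the carbonyl carbon gives a 7.7-fold higher number from compound 2 to compound 4 (0.89 log units; beyond the scatter). No evidence on the cause of this step is available.

On these data alone, it remains open whether the lower number of compound 2 is specific to nonyl or extends to a shorter or longer alkyl chain on that carbonyl carbon. A free primary amine at this chain carbon also remains to be placed in the series.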